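The source may report more compounds than this note shows. Statements on the series, on what has been measured and on what is new or still open speak of the compounds shown alone.

Of the compounds shown here, two have so far been measured in a functional assay on cells (Homo sapiens) for cytotoxicity, read by MTT assay, with a stated time of 48 h; a lower number here means a stronger inhibitor, a higher number a weaker inhibitor. Compound 1 `COc1ccc(CNC(=O)CC2c3ccccc3N=C(N(C)CCCCCN(C)C)N2c2ccc(-c3ccccc3)cc2)cc1` gives 2520 nM. Compound 2 `CN(C)CCN1CCN(C2=Nc3ccccc3C(CC(=O)NCc3ccc(F)cc3)N2c2ccc(-c3ccccc3)cc2)CC1` gives 4000 nM. These two numbers lie within the usual scatter of repeated measurements of one another, so neither compound can be called the stronger inhibitor on this evidence. Compound 3 `COc1ccc(CNC(=O)CC2c3ccccc3N=C(N3CCN(CCN(C)C)CC3)N2c2ccc(-c3ccccc3)cc2)cc1` has not yet been tested in this assay. It keeps the shared core of compound 2 and differs in one place: methoxy in place of fluoro on an aromatic carbon. Going by the values given here, no measured pair shows this single change on its own. Since compound 1, which also carries methoxy but with a different chain, gives 2520 nM close to compound 2, the step is expected to be small, a 1.1-fold lower number from compound 2 to compound 3 (0.06 log units; within the scatter), and not beyond the scatter. Compound 3 is estimated at 3500 nM, within 1500 nM to 8000 nM.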

Compound 3, half-maximal inhibitory concentration: 3820 nM
For compound 3 the middle estimate is 1.1-fold (0.04 log units) below the measured one; the range from low to high includes it.
By their numbers in this assay, from the lowest: compounds 1, 3 and 2 (each within the scatter of the next).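

Going by these compounds alone, compound 3 gives the first direct reading of 4-methoxybenzyl in place of 4-fluorobenzyl on the shared core: in this assay there is a 1.0-fold lower number from compound 2 to compound 3 (0.02 log units; within the scatter) and this lies within the scatter, so the assay does not separate these two groups at this position. Within the data shown here, it also gives the first comparison of the two side chains on an otherwise unchanged compound, 4-(2-(dimethylamino)ethyl)piperazin-1-yl in place of (5-(dimethylamino)pentyl)(methyl)amino, with a 1.5-fold higher number from compound 1 to compound 3 (0.18 log units; within the scatter) and again within the scatter. No outside evidence bears on either result.

The compounds shown leave open how a nitrile or a carboxylic acid on this aromatic carbon would read. They also leave open whether a side chain ending in a primary amine would stand apart from these three compounds.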